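Series notes: substituent swaps on the side-chain carbon

A few compounds are considered here, and "the series" means these few. Any claim that something is new, unique, unknown or untested is made for them only; others in the source may bear on it.

Of the compounds shown here, three of the shared core have been measured in a functional assay on CHO cells for antagonist activity at prostaglandin E2 receptor EP3 subtype (Homo sapiens), read by cAMP accumulation; on this read-out lower numbers stand for stronger inhibition and higher numbers for weaker inhibition. Compound 1 `CC(C)C(Nc1nnc[nH]1)c1ccc(-c2ccc3cccc(F)c3c2)[nH]c1=O` gives 185 nM. Compound 2 `CC(C)C(c1ncco1)c1ccc(-c2ccc3cccc(F)c3c2)[nH]c1=O` gives 64 nM. Compound 3 `CC(C)C(Cc1nnn[nH]1)c1ccc(-c2ccc3cccc(F)c3c2)[nH]c1=O` gives 134 nM. Compound 3 thus stands second highest of the three numbers, with compound 1 nearest, a 1.4-fold lower number from compound 1 to compound 3 (0.14 log units; within the scatter), and compound 2 furthest, a 2.1-fold higher number from compound 2 to compound 3 (0.32 log units; beyond the scatter). All three differ only on the saturated chain carbon bound to an aromatic carbon and a saturated chain carbon, and the steps there have stayed modest: a 2.9-fold lower number from compound 1 to compound 2 (0.46 log units; beyond the scatter).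

Compound 4 `CC(C)C(/C=C1\CCNC1=O)c1ccc(-c2ccc3cccc(F)c3c2)[nH]c1=O` is not yet measured. It differs from compound 3 as follows: a group of 7 heavy atoms (5 carbon, 1 nitrogen, 1 oxygen; one five-membered non-aromatic ring with 1 hetero atom) in place of a group of 6 heavy atoms (2 carbon, 4 nitrogen; one five-membered aromatic ring with 4 hetero atoms), on a saturated chain carbon bound to an aromatic carbon and a saturated chain carbon. Within the data shown here, the steps that bear on it are the two that remove or install the (1H-tetrazol-5-yl)methyl group, a 1.4-fold lower number from compound 1 to compound 3 (0.14 log units; within the scatter) and a 2.1-fold higher number from compound 2 to compound 3 (0.32 log units; beyond the scatter); both are small. Among the measured compounds shown here, no measured compound carries a non-aromatic ring at this position, so the direction is uncertain. In this assay the step is therefore expected to be small, a 1.2-fold lower number from compound 3 to compound 4 (0.09 log units; within the scatter), and compound 4 is estimated at 110 nM, with a range from 40 nM to 320 nM.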

Compound 4, half-maximal inhibitory concentration: 8.7 nM
The estimate for compound 4 lay 13-fold (1.10 log units) above the measured number; the whole stated range lies above it.
By their numbers in this assay, from the lowest: compound 4; then compound 2; then compounds 3 and 1 (each within the scatter of the next).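

Working notes after the latest result: in this assay, the saturated chain carbon bound to an aromatic carbon and a saturated chain carbon proves far more responsive than the earlier swaps showed, with the entering group of one five-membered non-aromatic ring giving a 15-fold lower number from compound 3 to compound 4 (1.19 log units; beyond the scatter) and a 7.4-fold lower number from compound 2 to compound 4 (0.87 log units; beyond the scatter) and a 21-fold lower number from compound 1 to compound 4 (1.33 log units; beyond the scatter). All three steps lie beyond the scatter and run the same way, so an aromatic ring at this place is not required for inhibition among these compounds. Nothing at hand bears on what lies behind this gain.

Still open is whether the gain follows the non-aromatic ring itself or the double bond outside it, as no compound shown separates the two. Also open, going by these compounds, is how an amine, a carboxylic acid or a longer chain would read at this place.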